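Swapping a tert-butyl benzyl for a dimethoxy benzyl

The source may hold more compounds than are shown below. What is called first, only, known or untested is meant among the compounds shown, and "the series" means these compounds.

Compound 1 `CC(C)(C)c1ccc(CNCCCNS(=O)(=O)c2cc(C(F)(F)F)cc(C(F)(F)F)c2)cc1` was tested in a functional assay on MIA PaCa-2 cells (Homo sapiens) for inhibition, read by MTT assay, with a stated time of 72 h (on this read-out higher numbers stand for weaker inhibition of growth and lower numbers for stronger inhibition of growth), where compound 1 gives 2300 nM. Compound 2 `O=S(=O)(NCCNCc1ccc(-c2ccccc2)cc1)c1cc(C(F)(F)F)cc(C(F)(F)F)c1` gives 2700 nM in this assay; the two numbers lie within the scatter of each other, so neither stands apart. Compound 3 `COc1ccc(CNCCCNS(=O)(=O)c2cc(C(F)(F)F)cc(C(F)(F)F)c2)cc1OC` has not yet been measured. It differs from compound 1 by 3,4-dimethoxyphenyl in place of 4-(tert-butyl)phenyl on a saturated chain carbon bound to an amine nitrogen. Going by the values given here, no measured pair shows this change. The step expected in this assay is a 2.2-fold higher number from compound 1 to compound 3 (0.34 log units; beyond the scatter), a rise somewhat beyond the scatter. Compound 3 is therefore estimated at 5000 nM, within 1500 nM to 15000 nM.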

Compound 3, concentration for 50% growth inhibition: 2800 nM
For compound 3 the middle estimate is 1.8-fold (0.25 log units) above the measured one, within the range that was stated.
By their numbers in this assay, from the lowest: compounds 1, 2 and 3 (each within the scatter of the next).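

In this assay, 3,4-dimethoxyphenyl in place of 4-(tert-butyl)phenyl on a saturated chain carbon bound to an amine nitrogen gives a 1.2-fold higher number from compound 1 to compound 3 (0.09 log units; within the scatter). This position therefore takes an all-carbon group and one bearing two oxygen atoms and two hydrogen-bond acceptors, and the read-out does not separate them. No measurement at hand offers an explanation for this result. As far as these compounds go, it remains open whether a benzyl group carrying a carboxylic acid or an amine would fall in the same range. From the compounds shown here alone, the effect of a longer chain linking the amine to the sulfonamide is also open.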